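A few compounds are considered here, and "the series" means these few. Any claim that something is new, unique, unknown or untested is made for them only; others in the source may bear on it.

Compound 1 `CC(C)C[C@H](N)c1cc(C(F)(F)F)ccc1N1CCN(C(=O)CCC(N)=O)CC1` is the starting point of the series. In an assay on HEK293 cells for displacement of a labelled ligand from Melanocortin receptor 4 (Homo sapiens) (on this read-out higher numbers stand for weaker inhibition and lower numbers for stronger inhibition), compound 1 gives only a limit, > 10000 nM. Compound 2 `CC(C)C[C@H](N)c1cc(C(F)(F)F)ccc1N1CCN(C(=O)COc2cccc(Cl)c2)CC1` carries a 3-chlorophenoxy group in place of the carbamoylmethyl group, and in this assay compound 2 gives 2600 nM. Going by the values given here, the step of an at least 3.8-fold lower number from compound 1 to compound 2 (0.58 log units; beyond the scatter) is the only measured change, and its size is known only through (the limit of > 10000 nM in this assay, at which 1 of the 2 values shown sits). Among the compounds with values here, compound 2 therefore stands as the one actual number in this assay, the other value being a limit. Compound 3 `Cc1ccc(CC(C)C(=O)N2CCN(c3ccc(C(F)(F)F)cc3[C@@H](N)CC(C)C)CC2)cc1C` alters the same carbonyl carbon again: 1-(3,4-dimethylbenzyl)ethyl in place of (3-chlorophenoxy)methyl on a carbonyl carbon. Within the data shown here, only the step from compound 1 to compound 2 bears on this, and it shows that the group on this carbonyl carbon can shift the number by at least a modest amount. Compound 3 is expected to give about 1800 nM, within a range from 400 nM to 8000 nM. The step of a 1.4-fold lower number from compound 2 to compound 3 (0.16 log units; within the scatter) is thus estimated to stay within the scatter.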

Compound 3, inhibition constant: 240 nM
For compound 3 the middle estimate is 7.5-fold (0.88 log units) above the measured one; measured number outside the range, below it.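

In this assay, going by these compounds alone, the change at this carbonyl carbon gives an 11-fold lower number from compound 2 to compound 3 (1.03 log units; beyond the scatter), which is the first step here that joins two actual numbers. The leaving (3-chlorophenoxy)methyl and the entering 1-(3,4-dimethylbenzyl)ethyl each hold one six-membered aromatic ring of carbon only, so the presence of such a ring does not by itself set the number; the two groups differ in their heavy atoms, with the oxygen and chlorine gone and the methyl groups added. Replacing the 2-carbamoylethyl group of compound 1, whose value is a limit, gives an at least 41-fold lower number from compound 1 to compound 3 (1.61 log units; beyond the scatter), and the size of that step is known only through: the limit of > 10000 nM in this assay, at which 1 of the 3 values shown sits.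

The compounds shown leave open which part of the entering group accounts for the step, as its differences all arrive together. Also open, as far as these compounds go, is how an amine or a carboxylic acid on the aromatic ring, or a longer chain leading to it, would read.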